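Swapping the phenyl ether for a trichlorophenyl ether

A few compounds are considered here, and "the series" means these few. Any claim that something is new, unique, unknown or untested is made for them only; others in the source may bear on it.

Three measured compounds share one core and differ only in the group on an oxygen on an aromatic ring. Compound 1 `Cc1cccc(Oc2nc(Nc3ccc(C#N)cc3)nc3ccccc23)c1` gives 355000 nM in an ADME assay on MT4 cells (Homo sapiens) for cytotoxicity, read by MTT assay, with a stated time of 4 days; on this read-out lower numbers stand for higher toxicity in this test and higher numbers for lower toxicity in this test. Compound 2 `COc1cc(C#N)ccc1Oc1nc(Nc2ccc(C#N)cc2)nc2ccccc12` gives only a limit in this assay, >= 140000 nM, which is the limit (the limit of >= 140000 nM in this assay, at which 1 of the 3 values shown sits). Compound 3 `N#Cc1ccc(Nc2nc(Oc3ccc(Br)cc3)c3ccccc3n2)cc1` gives 215000 nM in this assay, the lowest of the two actual numbers, with compound 1 as its nearest neighbour; the step of a 1.7-fold lower number from compound 1 to compound 3 (0.22 log units; within the scatter) is within the scatter, so no difference between these two can be read. The steps a step that the limit leaves unreadable from compound 1 to compound 2 and a step that the limit leaves unreadable from compound 2 to compound 3 cannot be sized. Compound 4 `N#Cc1ccc(Nc2nc(Oc3c(Cl)cc(Cl)cc3Cl)c3ccccc3n2)cc1` carries the change (2,4,6-trichlorophenyl in place of 4-bromophenyl on an oxygen on an aromatic ring). Among the compounds with values here, the only readable step on this position, a 1.7-fold lower number from compound 1 to compound 3 (0.22 log units; within the scatter), stayed within the scatter, so an exchange of the aromatic group on the oxygen has not yet moved this read-out beyond the scatter. Compound 4 is therefore expected to stay close to compound 3, a step of about a 1.1-fold lower number from compound 3 to compound 4 (0.03 log units; within the scatter), and its estimated value is 200000 nM, between 80000 nM and 400000 nM.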

Compound 4, half-maximal cytotoxic concentration: 56000 nM
The estimate for compound 4 lay 3.6-fold (0.55 log units) above the measured number, outside the stated range (below it).
By their numbers in this assay, from the lowest: compound 4; then compounds 3 and 1 (each within the scatter of the next).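

The group on the oxygen can move this read-out after all: in this assay the step of a 3.8-fold lower number from compound 3 to compound 4 (0.58 log units; beyond the scatter) and the step of a 6.3-fold lower number from compound 1 to compound 4 (0.80 log units; beyond the scatter) both point towards higher toxicity in this test, which the earlier readable step on this position did not. Compound 2 has only a limit, >= 140000 nM in this read-out. Even so, the step of an at least 2.5-fold lower number from compound 2 to compound 4 (0.39 log units; beyond the scatter) can be read and points the same way.

Nothing measured here says why the number falls, or whether the three chlorine atoms act together or one of them is enough. From the compounds shown here alone, whether a phenyl ring carrying an amine or a carboxylic acid on the same oxygen would give a number like that of compound 4 stays open.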